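A few compounds are considered here, and "the series" means these few. Any claim that something is new, unique, unknown or untested is made for them only; others in the source may bear on it.

Compound 1 `CCOC(=O)CCCCCOc1cccc(CN(C(=O)c2ccccc2)C(C)C)c1`: in an ADME assay on Raji cells (Homo sapiens) for cytotoxicity, read by CellTiter-Glo and resazurin assay, with a stated time of 72 h (a higher number here means that more compound is needed for the effect, a lower number that less compound is needed), compound 1 gives > 26000 nM, which is a limit of the assay.
Compound 2 `C=CCCC1=NCC(O[Si](C)(C)C(C)(C)C)c2cc(OC)c(OC)cc21`: in this assay compound 2 gives > 13000 nM, again a limit of the assay.

Among the measured compounds shown here, neither measured value is a number, so no step between measured compounds can be drawn. Compound 2 stands at the limit of > 13000 nM in this assay, at which 1 of the 2 values shown sits. Compound 3 `C=CCCC1=NCC(OC(C)=O)c2cc(OC)c(OC)cc21` differs from compound 2 by a group of 3 heavy atoms (2 carbon, 1 oxygen; no ring) in place of a group of 7 heavy atoms (6 carbon, 1 silicon; no ring), on an oxygen on a saturated carbon, a group of 3 heavy atoms in place of a group of 7 heavy atoms, on an oxygen on a saturated carbon. For compound 3 the step that the limit leaves unreadable from compound 2 to compound 3 is expected to show no clear direction beyond the scatter. Compound 3 is estimated at 20000 nM, between 8000 nM and 50000 nM, most likely reported as a limit.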

Compound 3, half-maximal effective concentration: > 13000 nM
Compound 3 ended at the assay's limit; the forecaster's own chance of this, stated with the estimate: 70%; the middle value does not contradict the limit.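

Compound 2 and compound 3 both end at a limit in this assay, not at a number, so no step can be read between them. From the compounds shown here alone, whether acetyl, in place of the larger group on that oxygen, changes the cytotoxic concentration at all stays open.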